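A Carbamoylmethyl Exchange on the Sulfur-Bound Chain

The compounds below may be only part of what the source reports. "The series", "measured", "known", "first", "only" and "open" are said of these compounds alone.

In a functional assay on HT cells (Homo sapiens) for antiproliferative activity, read by fluorescence, with a stated time of 72 h (a lower number here means a stronger inhibitor of growth, a higher number a weaker inhibitor of growth), compound 3 (`CC(C)c1n[nH]c2c(NCc3ccc(-c4ccccn4)cc3)nc(SCC(C)(C)N)nc12`) gives 85 nM. Two compounds with the same core sit alongside it: compound 1 (`CC(C)c1n[nH]c2c(NCc3ccc(-c4ccccn4)cc3)nc(SCC3CNC(=O)O3)nc12`) at 80 nM and compound 2 (`CC(C)c1n[nH]c2c(NCc3ccc(-c4ccccn4)cc3)nc(SCC(O)CN)nc12`) at 55 nM. Compound 3 therefore stands level with both, and the three form a single group on these numbers.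

Compound 4 (`CC(C)c1n[nH]c2c(NCc3ccc(-c4ccccn4)cc3)nc(SCCC(N)=O)nc12`) has not yet been measured. It carries carbamoylmethyl in place of 1-amino-1-methylethyl on a saturated chain carbon bound to a sulfur. Among the compounds with values here, no measured step makes this exact exchange, but all three steps alter the same place. The closest guide is the exchange between 2-oxo-1,3-oxazolidin-5-yl and 1-amino-1-methylethyl, which gives a 1.1-fold higher number from compound 1 to compound 3 (0.03 log units; within the scatter). The other two are a 1.5-fold higher number from compound 2 to compound 3 (0.19 log units; within the scatter) and a 1.5-fold lower number from compound 1 to compound 2 (0.16 log units; within the scatter). On these data alone, none of these steps exceeds the scatter, so no shift in either direction is expected, although carbamoylmethyl itself remains untested. The expected change is a 1.1-fold higher number from compound 3 to compound 4 (0.05 log units; within the scatter), which would not be distinguishable from the scatter. For compound 4 the estimated value is 95 nM, with an expected range from 40 nM to 230 nM.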

Compound 4, concentration for 50% growth inhibition: 120 nM
Estimate against measurement, compound 4: 1.3-fold (0.10 log units) below; the measured number falls inside the stated range.
By their numbers in this assay, from the lowest: compounds 2, 1, 3 and 4 (each within the scatter of the next, the first and the last beyond it).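

Among the earlier compounds, no step at this place, on a saturated chain carbon bound to a sulfur, went beyond the scatter in this assay, but carbamoylmethyl yields one such step, a modest one: a 2.2-fold higher number from compound 2 to compound 4 (0.34 log units; beyond the scatter). The other two exchanges stay within the scatter, namely a 1.4-fold higher number from compound 3 to compound 4 (0.15 log units; within the scatter) and a 1.5-fold higher number from compound 1 to compound 4 (0.18 log units; within the scatter), so carbamoylmethyl separates compound 4 clearly only from compound 2, and the four compounds still span a narrow band of values. The presence of an amine in the leaving group does not by itself mark out that one step, since compound 3 also carries an amine and stays within the scatter of compound 4, and nothing available here accounts for the difference between compound 2 and compound 4.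

What the compounds shown leave open is how far this place can be pushed, for example by a carboxylic acid or a longer chain ending in an amine, since every group here stays close to the same range. On these data alone, it also remains open whether the modest step from 2-amino-1-hydroxyethyl to carbamoylmethyl would persist on a different core.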